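The source may report more compounds than this note shows. Statements on the series, on what has been measured and on what is new or still open speak of the compounds shown alone.

Working notes on the series. Compound 1 `COCc1c(C)nc2c(OCc3ccccc3)cccn12` in a functional assay on the whole organism (stomach) for inhibition, with Canis familiaris (Canis lupus familiaris) as the target, at a dose of 5 mg/kg by the intravenous route (on this read-out higher numbers stand for a stronger effect at the one dose given and lower numbers for a weaker effect), gives 29%, and compound 2 `Cc1nc2c(OCc3ccccc3)cccn2c1CC(=O)O` in this assay gives 24%. Among the compounds with values here, the one measured step, a number 5 percentage points lower from compound 1 to compound 2 (within the scatter), is carboxy in place of methoxy on a saturated chain carbon bound to an aromatic carbon. On the numbers shown compound 2 holds the lower of the two, with compound 1 as its only neighbour, the gap between them within the scatter.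

Compound 3 `Cc1nc2c(OCc3ccccc3)cccn2c1COC(=O)N(C)C` has not been measured and differs from compound 2 as (dimethylcarbamoyl)oxy in place of carboxy on a saturated chain carbon bound to an aromatic carbon. Within the data shown here, the only measured step at this place is a number 5 percentage points lower from compound 1 to compound 2 (within the scatter), which stayed within the scatter; no measured pair covers (dimethylcarbamoyl)oxy itself. From this, no step beyond the scatter is expected in this assay for compound 3, in either direction. Compound 3 is expected to give 26% in this assay, with a range from 10% to 42%. The expected step is a number 2 percentage points higher from compound 2 to compound 3 (within the scatter).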

Compound 3, a percentage reported as inhibition, in the whole organism at one dose (the size of the read-out at that dose, not a potency): 23%
The estimate for compound 3 lay 3 percentage points above the measured number; low and high end bracket the measured number.
By their numbers in this assay, from the lowest: compounds 3, 2 and 1 (each within the scatter of the next).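

The place on a saturated chain carbon bound to an aromatic carbon now also carries (dimethylcarbamoyl)oxy, with 6 heavy atoms against 3 for carboxy and 0 hydrogen-bond donors against 1, and this assay shows a number 1 percentage points lower from compound 2 to compound 3 (within the scatter). Dimethylcarbamoyl in place of methyl on an oxygen on a saturated carbon gives a number 6 percentage points lower from compound 1 to compound 3 (within the scatter), so all three groups seen at this place now lie within the scatter of one another, a wider span of groups than the single earlier step covered. Nothing at hand explains why these steps stay within the scatter.

As far as these compounds go, whether an amine or a longer chain at this place would give a step beyond the scatter remains open. From the compounds shown here alone, the shared core is the same in all three compounds, and the single dose gives the size of an effect rather than a potency, so its contribution and any potency differences also remain open.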